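The source may report more compounds than this note shows. Statements on the series, on what has been measured and on what is new or still open speak of the compounds shown alone.

Compound 1, with structure `O=c1[nH]/c(=N\OCCOc2ccccc2)ccn1[C@@H]1O[C@H](COP(=O)(O)OP(=O)(O)OP(=O)(O)O)[C@@H](O)[C@H]1O`, is the reference point of this pair. In a functional assay on 1321-N1 cells for agonist activity at P2Y purinoceptor 4 (Homo sapiens), read by scintillation counting and inositol phosphate accumulation (on this read-out lower numbers stand for an effect already at smaller amounts and higher numbers for an effect only at larger amounts of compound), compound 1 gives 430 nM. Compound 2, with structure `O=c1[nH]/c(=N\OCCCc2cccc(F)c2)ccn1[C@@H]1O[C@H](COP(=O)(O)OP(=O)(O)OP(=O)(O)O)[C@@H](O)[C@H]1O`, differs from it in one place: it carries a 3-fluorobenzyl in place of the phenoxy on a saturated chain carbon, two bonds along the chain from an oxygen. In this assay compound 2 gives 100 nM, and the step is a 4.3-fold lower number from compound 1 to compound 2 (0.63 log units; beyond the scatter). Among the two numbers measured, compound 2 thus stands lowest.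

Compound 3, with structure `O=c1[nH]/c(=N\OCCCc2ccc(F)cc2)ccn1[C@@H]1O[C@H](COP(=O)(O)OP(=O)(O)OP(=O)(O)O)[C@@H](O)[C@H]1O`, is not yet measured. Its difference from compound 2 is 4-fluorophenyl in place of 3-fluorophenyl on a saturated chain carbon, three bonds along the chain from an oxygen. Within the data shown here, the only measured step, from compound 1 to compound 2, swaps one whole group for another and does not move a fluorine around a ring, so it bears on this change only loosely: it shows that this end of the molecule can shift the number, but nothing here tells in which direction a fluorine shift would go. The step from compound 2 to compound 3 is therefore expected to be a 1.3-fold higher number from compound 2 to compound 3 (0.11 log units; within the scatter), within the usual scatter. Compound 3 is estimated to give 130 nM in this assay, with a range from 45 nM to 400 nM.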

Compound 3, half-maximal effective concentration: 105 nM
Compound 3: middle estimate off by 1.2-fold (0.09 log units), on the high side, and the stated range covers the measured number.
By their numbers in this assay, from the lowest: compounds 2 and 3 (each within the scatter of the next); then compound 1.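

In this assay, moving the fluorine from 3-fluorophenyl to 4-fluorophenyl, on a saturated chain carbon three bonds along the chain from an oxygen, gives a 1.1-fold higher number from compound 2 to compound 3 (0.02 log units; within the scatter) and so leaves compound 2 and compound 3 indistinguishable: at this position, the two fluorine placements cannot be told apart by this read-out. The other new comparison, 4-fluorobenzyl in place of phenoxy, gives a 4.1-fold lower number from compound 1 to compound 3 (0.61 log units; beyond the scatter) and shows that the change away from compound 1 seen earlier with compound 2 is not limited to the 3-fluorophenyl form, as it appears with the 4-fluorophenyl form too. No supporting measurement is available to explain why the two placements give matching results.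

As far as these compounds go, whether the fluorine matters at all remains open, and a plain phenyl on the same chain, or a chlorine in place of the fluorine, would address that question. From the compounds shown here alone, how the number responds to a longer chain carrying the ring, or to an amine on the ring, also remains unknown.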